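Pyridyl ether to cyanophenyl ether: an expected cytotoxicity step

The source may hold more compounds than are shown below. What is called first, only, known or untested is meant among the compounds shown, and "the series" means these compounds.

Three analogues sharing one core have been tested in an ADME assay on PBMC cells (Homo sapiens) for cytotoxicity; a higher number here means that more compound is tolerated, a lower number that less compound is tolerated. Compound 1 `CC(CCNC(=O)c1c(Cl)cncc1Cl)N1CCC(C(Oc2cccc(C(=O)O)n2)c2ccc(C(F)(F)F)cc2)CC1` gives 28700 nM. Compound 2 `CC(CCNC(=O)c1c(Cl)cncc1Cl)N1CCC(C(Oc2cccc(F)c2)c2ccc(C(F)(F)F)cc2)CC1` gives 5400 nM, and compound 3 `CC(CCNC(=O)c1c(Cl)cncc1Cl)N1CCC(C(Oc2ccccn2)c2ccc(C(F)(F)F)cc2)CC1` gives 34100 nM. Compound 3 holds the highest of the three numbers; its gap to compound 1 lies within the scatter, a 1.2-fold higher number from compound 1 to compound 3 (0.07 log units; within the scatter), whereas a 6.3-fold higher number from compound 2 to compound 3 (0.80 log units; beyond the scatter) stands beyond it.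

The next compound, compound 4 `CC(CCNC(=O)c1c(Cl)cncc1Cl)N1CCC(C(Oc2ccccc2C#N)c2ccc(C(F)(F)F)cc2)CC1`, has not yet been measured in this assay. It differs from compound 3 in one place: 2-cyanophenyl in place of pyridin-2-yl on an oxygen on a saturated carbon.

Going by the values given here, two measured steps bear on this change. Replacing a six-membered aromatic ring of carbon only with a ring holding one nitrogen, a 6.3-fold higher number from compound 2 to compound 3 (0.80 log units; beyond the scatter), raised the number, and the move in the other direction, a 5.3-fold lower number from compound 1 to compound 2 (0.73 log units; beyond the scatter), lowered it. Among the compounds with values here, compound 4 again carries a ring of carbon only on this oxygen, though its substituent is a nitrile rather than fluorine, a variation for which no measured pair exists. Compound 4 is therefore expected to show a lower number than compound 3. For compound 4 the expected step is a 2.8-fold lower number from compound 3 to compound 4 (0.45 log units; beyond the scatter). The estimate for compound 4 is 12000 nM, within a range from 4000 nM to 36000 nM.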

Compound 4, half-maximal cytotoxic concentration: 17000 nM
The estimate for compound 4 lay 1.4-fold (0.15 log units) below the measured number, within the range that was stated.
By their numbers in this assay, from the lowest: compound 2; then compounds 4, 1 and 3 (each within the scatter of the next).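

In this assay, a ring of carbon only on this oxygen no longer goes together with the low number of compound 2: the change to 2-cyanophenyl from 3-fluorophenyl gives a 3.1-fold higher number from compound 2 to compound 4 (0.50 log units; beyond the scatter) and so separates the two carbon-only rings at this position. Compound 4 cannot be told apart from either nitrogen-bearing ring, with a 2.0-fold lower number from compound 3 to compound 4 (0.30 log units; within the scatter) against pyridin-2-yl and a 1.7-fold lower number from compound 1 to compound 4 (0.23 log units; within the scatter) against 6-carboxypyridin-2-yl. Among the four compounds only compound 2 now stands apart from the others, so the absence of a ring nitrogen does not by itself go with a lower number, as the two earlier steps around compound 2 alone had suggested.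

Nothing available accounts for the gap between the 2-cyanophenyl and 3-fluorophenyl ethers. The compounds shown also leave open whether the nitrile or the fluorine decides the outcome, and how a methoxy group or an amine on the same phenyl ring would fare in this assay on this oxygen on a saturated carbon.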